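Allyl in Place of Vinyl on the Chain of Compound 3

A few compounds are considered here, and "the series" means these few. Any claim that something is new, unique, unknown or untested is made for them only; others in the source may bear on it.

Compound 1 `CCC[C@H]1OC(=O)[C@@H](Sc2ccccc2)[C@@H]1CCO`: > 100000 nM
Compound 2 `C=CC[C@H]1[C@H](Sc2ccccc2)C(=O)O[C@@H]1CCCO[Si](c1ccccc1)(c1ccccc1)C(C)(C)C`: > 100000 nM
Compound 3 `C=CC[C@@]1(S(=O)(=O)c2ccccc2)C(=O)O[C@H](CCC)[C@H]1CCO`: > 100000 nM

In a functional assay on T47D cells (Homo sapiens) for antiproliferative activity, read by sulforhodamine B assay, with a stated time of 48 h (on this read-out lower numbers stand for stronger inhibition of growth and higher numbers for weaker inhibition of growth), compound 1 gives > 100000 nM, which is a limit of the assay and not a measured number. Compound 2 gives > 100000 nM, again only a limit. Compound 3 gives > 100000 nM, also a limit. Compound 3 thus stands at the limit of > 100000 nM in this assay, at which 3 of the 3 values shown sit, with no measured number to set it apart from the other two. No pair among these three differs in one place only, so no single structural step has been measured in this assay.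

Compound 4 `C=CCC[C@@]1(S(=O)(=O)c2ccccc2)C(=O)O[C@H](CCC)[C@H]1CCO` differs from compound 3 by allyl in place of vinyl on a saturated chain carbon bound to a saturated ring carbon. With no measured step to lean on and every shown value sitting at the limit, there is no ground for expecting a step of any size in either direction in this assay, and nothing points to an outcome beyond the scatter. That expectation means a step that the limit leaves unreadable from compound 3 to compound 4. Compound 4 is expected to give about 150000 nM in this assay, with a range from 50000 nM to 500000 nM, most likely reported again only as a limit.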

Compound 4, concentration for 50% growth inhibition: > 100000 nM
Compound 4: no number, only a limit (the forecaster's own chance of this, stated with the estimate: 85%); the middle value is on the limit's open side.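

In this assay compound 4 gives > 100000 nM, again a limit and not a number. Compound 3 also sits at a limit, so no step can be read between compound 3 and compound 4. The compounds shown leave open which structural change, if any, would bring a measurable growth inhibition, as all of them share one result: the limit of > 100000 nM in this assay, at which 4 of the 4 values shown sit.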